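Cytotoxicity notes: nitro for fluoro on the anilide ring

The compounds below may be only part of what the source reports. "The series", "measured", "known", "first", "only" and "open" are said of these compounds alone.

Measured so far in an ADME assay on MT4 cells (Homo sapiens) for cytotoxicity, read by MTT assay; a lower number here means that less compound is tolerated, a higher number that more compound is tolerated:
compound 1 `Cc1ccccc1NC(=O)CSc1nccn1-c1ccc(Cl)cc1` gives 160000 nM
compound 2 `COc1ccc(-n2ccnc2SCC(=O)Nc2ccccc2[N+](=O)[O-])cc1` gives 161000 nM
compound 3 `O=C(CSc1nccn1-c1cccc2ccccc12)Nc1ccccc1F` gives 34700 nM

Compound 3 stands lowest of the three numbers in this assay; compound 1 and compound 2 both lie above it by a margin beyond the scatter, so compound 3 is the least tolerated of the three measured, while compound 1 and compound 2 cannot be set in order against each other.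

Compound 4 `O=C(CSc1nccn1-c1cccc2ccccc12)Nc1ccccc1[N+](=O)[O-]` has not yet been measured. It differs from compound 3 in one place: nitro in place of fluoro on an aromatic carbon. For the measured compounds named here, no measured pair shows this change on its own. Compound 2 carries the nitro group as well, but it also differs from compound 3 in the other aryl ring, so its value is only a loose pointer.

The step from compound 3 to compound 4 in this assay is expected to be a moderate rise, a 1.6-fold higher number from compound 3 to compound 4 (0.20 log units; within the scatter), leaning that way since compound 2 gives 161000 nM. Compound 4 is therefore expected to give 55000 nM, with a range from 17000 nM to 160000 nM.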

Compound 4, half-maximal cytotoxic concentration: 28800 nM
The estimate for compound 4 lay 1.9-fold (0.28 log units) above the measured number, and the stated range covers the measured number.
By their numbers in this assay, from the lowest: compounds 4 and 3 (each within the scatter of the next); then compounds 1 and 2 (each within the scatter of the next).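

In this assay, going from 2-fluorophenyl to 2-nitrophenyl on this aromatic carbon, ortho to a large group, reads as a 1.2-fold lower number from compound 3 to compound 4 (0.08 log units; within the scatter), so exchanging one heavy atom for three, with two hydrogen-bond acceptors entering, leaves the number in place. Compound 2 carries the same 2-nitrophenyl and gives 161000 nM, while compound 4 gives 28800 nM, so the nitro group alone does not set the number, and these two compounds differ in the other aryl ring. Nothing measured here bears on why the number holds across this change.

Open, from the compounds shown here alone, is whether an amine or a carboxylic acid on the same aromatic carbon would also leave the number in place. Also open, going by these compounds, is whether the fluoro-to-nitro change reads the same with a different group on the other aryl ring.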